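From Carboxy to Propylcarbamoyl: Expected Cytotoxicity

The source may hold more compounds than are shown below. What is called first, only, known or untested is meant among the compounds shown, and "the series" means these compounds.

Compound 3 `O=C(O)c1cccn1-c1ccc2c(c1)B(O)OC2` carries a carboxy group on the shared core. In an ADME assay on L929 cells (Mus musculus) for cytotoxicity, read by resazurin assay, with a stated time of 72 h (a lower number here means a stronger inhibitor, a higher number a weaker inhibitor), compound 3 gives > 10 ug/mL, which is a limit of the assay rather than a number. Compound 2 `OB1OCc2ccc(-n3cccc3)cc21` gives > 10 ug/mL, also a limit. Compound 1 `COc1ccc(S(=O)(=O)c2cn(-c3ccc4c(c3)B(O)OC4)c3ccccc23)cc1` gives > 10 ug/mL, likewise a limit. The size of the step that the two limits leave unreadable from compound 2 to compound 3 cannot be read because of the limit of > 10 ug/mL in this assay, at which 3 of the 3 values shown sit. Compound 4 `CCCNC(=O)c1cccn1-c1ccc2c(c1)B(O)OC2` differs from compound 3 by propylamino in place of hydroxy on a carbonyl carbon. Among the compounds with values here, no measured step reports a number on either side of such a change, so no shift beyond the scatter is expected in either direction. Compound 4 is therefore estimated at 15 ug/mL, between 5 ug/mL and 50 ug/mL. The expected step is a step that the limit leaves unreadable from compound 3 to compound 4, essentially none in size.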

Compound 4, half-maximal inhibitory concentration: > 10 ug/mL
Compound 4 ended at the assay's limit (the forecaster's own chance of this, stated with the estimate: 80%); the middle value is on the limit's open side.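

Within the data shown here, no step to compound 4, from compound 2 or from compound 3, can be read, because both sides of each are limits: the limit of > 10 ug/mL in this assay, at which 4 of the 4 values shown sit.

The compounds shown leave open at what concentration any of them becomes toxic in this assay, and so whether carboxy or propylcarbamoyl changes that concentration.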